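This account rests on a few compounds, and the source may have more. Where it says the series, first, only, none or still open, it means among the compounds named here.

Measured compounds in the series:
compound 1, `COc1ccc(/C=C/C(=O)c2ccc(OC)c3c2OC(C)(C)C=C3)cc1OCCCN(C)C` — 8600 nM
compound 2, `COc1cccc(C(=O)Oc2cc(/C=C/C(=O)c3ccc(OC)c4c3OC(C)(C)C=C4)ccc2OC)c1` — > 10000 nM

For the measured compounds named here, in an ADME assay on L02 cells (Homo sapiens) for cytotoxicity, read by MTT assay (on this read-out higher numbers stand for weaker inhibition and lower numbers for stronger inhibition), compound 1 gives 8600 nM, the only number so far. For compound 2 the assay returns only the limit > 10000 nM, so the step of an at least 1.1-fold higher number from compound 1 to compound 2 (0.06 log units; that floor lies within the scatter) has a floor that lies within the scatter and gives no direction that can be trusted; it rests on the limit of > 10000 nM in this assay, at which 1 of the 2 values shown sits, alone.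

Compound 3, `COc1ccc(/C=C/C(=O)c2ccc(OC)c3c2OC(C)(C)C=C3)cc1CS(C)(=O)=O`, is the next member, differing from compound 1 as follows: (methylsulfonyl)methyl in place of 3-(dimethylamino)propoxy on an aromatic carbon. Going by the values given here, the one measured step, from compound 1 to compound 2, also replaces the 3-(dimethylamino)propyl group on that oxygen, but by a (3-methoxyphenyl)carbonyl, not by (methylsulfonyl)methyl, and its size is only a floor. It therefore bears on compound 3 only loosely. Nothing in the two values argues for a step in this assay beyond the scatter, with some chance that compound 3 also lands at the limit. The expected step is a 1.2-fold higher number from compound 1 to compound 3 (0.07 log units; within the scatter), and compound 3 is estimated at 10000 nM, within 5000 nM to 20000 nM.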

Compound 3, half-maximal inhibitory concentration: > 10000 nM
Compound 3: only a limit was reported; the forecaster's own chance of this, stated with the estimate: 45%; the middle value sits exactly at the limit.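

In this assay compound 3 is reported only as a limit, > 10000 nM. Putting (methylsulfonyl)methyl in place of 3-(dimethylamino)propoxy on this aromatic carbon, ortho to the methoxy group, removes the chain's nitrogen and the oxygen attached to the ring, yet the result is an at least 1.1-fold higher number from compound 1 to compound 3 (0.06 log units; that floor lies within the scatter), so this change gives no direction that can be trusted. This position has now taken a second replacement of the side chain of compound 1 without yielding a second number, and the step between compound 2 and compound 3 cannot be read, leaving the series mostly at one ceiling: the limit of > 10000 nM in this assay, at which 2 of the 3 values shown sit.

Still open, as far as these compounds go, is whether any group at this position gives a number clearly apart from that of compound 1, for example a primary amine, a carboxylic acid or a longer chain ending in a dimethylamino group. Also open, from the compounds shown here alone, is how far compound 2 and compound 3 lie past their limits, and so whether the two differ from each other or from compound 1 at all.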